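The source may hold more compounds than are shown below. What is called first, only, known or untested is meant among the compounds shown, and "the series" means these compounds.

Three compounds share one core and differ only in the group carried on the carbonyl carbon. Compound 1 `CCCOC(=O)C1=C(C)NC(=O)NC1c1ccoc1` gives 1190 nM in an assay on membranes from HEK293 cells for displacement of a labelled ligand from adenosine receptor A2b (Homo sapiens), read by scintillation counting, with a stated time of 30 min; a higher number here means a weaker inhibitor, a lower number a stronger inhibitor. Compound 2 `CC1=C(C(=O)OCc2ccccc2)C(c2ccoc2)NC(=O)N1` gives 6650 nM in this assay, so that a 5.6-fold higher number from compound 1 to compound 2 (0.75 log units; beyond the scatter). Compound 3 `CC1=C(C(=O)SC(C)C)C(c2ccoc2)NC(=O)N1` gives 637 nM in this assay, and here a 1.9-fold lower number from compound 1 to compound 3 (0.27 log units; within the scatter). Compound 3 thus holds the lowest of the three numbers, though its gap to compound 1 lies within the scatter, while its gap to compound 2 lies beyond it.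

Compound 4 `CCC(C)OC(=O)C1=C(C)NC(=O)NC1c1ccoc1` has not been measured in this assay. Compared with compound 3 it carries sec-butoxy in place of isopropylsulfanyl on a carbonyl carbon. For the measured compounds named here, two measured steps bear on this change. The first is a 1.9-fold lower number from compound 1 to compound 3 (0.27 log units; within the scatter), which is close to the same exchange run the other way and stayed within the scatter. The second is a 5.6-fold higher number from compound 1 to compound 2 (0.75 log units; beyond the scatter), which shows that a different chain at this carbon went with a clearly higher number. Going by the values given here, no measured pair shows a branched chain at this carbon, so that part of the change rests on no data. Compound 4 is therefore expected to show a 2.2-fold higher number from compound 3 to compound 4 (0.34 log units; beyond the scatter), a step that may well stay within the scatter. Compound 4 is expected to give 1400 nM in this assay, with a likely range from 450 nM to 4500 nM.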

Compound 4, inhibition constant: 201 nM
Compound 4: the middle estimate sits 7.0-fold (0.84 log units) above what was measured, outside the stated range (below it).
By their numbers in this assay, from the lowest: compound 4; then compounds 3 and 1 (each within the scatter of the next); then compound 2.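

Among the compounds shown, a branched chain on the oxygen is the first change at this carbonyl carbon to lower the number beyond the scatter in this assay: sec-butoxy in place of propoxy gives a 5.9-fold lower number from compound 1 to compound 4 (0.77 log units; beyond the scatter) and so separates two chains that both leave the carbonyl through an oxygen. The exchange of isopropylsulfanyl for sec-butoxy gives a 3.2-fold lower number from compound 3 to compound 4 (0.50 log units; beyond the scatter), so compound 4 stands clearly below compound 3, whereas the earlier step between compound 1 and compound 3 stayed within the scatter. Sec-butyl in place of benzyl on the same oxygen gives a 33-fold lower number from compound 2 to compound 4 (1.52 log units; beyond the scatter), the largest step in this set, which shows how widely the number can move with the group at this one position.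

Still open, going by these compounds, is whether the gain belongs to branching as such, since a tert-butoxy group, an isopropoxy group or a longer branched chain such as pentan-2-yloxy would each test that directly, and whether a sec-butylsulfanyl group would recover the same number. Nothing measured here gives a reason why sec-butoxy goes with the lowest number of the four.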